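A few compounds are considered here, and "the series" means these few. Any claim that something is new, unique, unknown or untested is made for them only; others in the source may bear on it.

Compound 1 `O=C(CCN1CCN(c2ccc([N+](=O)[O-])cc2)CC1)c1ccc(Br)cc1`: 79800 nM
Compound 2 `O=C(CCN1CCN(c2ccc(Cl)cc2)CC1)c1ccc(F)c(Br)c1`: 206000 nM

In an ADME assay on Vero cells (Chlorocebus sabaeus) for cytotoxicity, read by resazurin assay, with a stated time of 72 h (on this read-out higher numbers stand for weaker inhibition and lower numbers for stronger inhibition), compound 2 gives 206000 nM and compound 1 gives 79800 nM. Compound 2 has the higher of the two numbers, and the gap between them lies beyond the scatter. Compound 3 `O=C(CCN1CCN(c2ccc([N+](=O)[O-])cc2)CC1)c1ccc(F)c(Br)c1` keeps the rest of compound 2 but has nitro in place of chloro on an aromatic carbon, para to a large group (nitro in place of chloro on an aromatic carbon). Going by the values given here, compounds 1 and 2 differ in more than one place, so no measured step shows this change from 4-chlorophenyl to 4-nitrophenyl on its own. Compound 1 does carry the 4-nitrophenyl group, and its value of 79800 nM suggests a lower number in this assay. A modest move towards stronger inhibition is therefore expected, with the estimated step being a 1.8-fold lower number from compound 2 to compound 3 (0.25 log units; within the scatter). Compound 3 is estimated at 115000 nM, with an expected range of 50000 nM to 250000 nM.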

Compound 3, half-maximal inhibitory concentration: 256000 nM
For compound 3 the middle estimate is 2.2-fold (0.35 log units) below the measured one; the measured number lies above the stated range.
By their numbers in this assay, from the lowest: compound 1; then compounds 2 and 3 (each within the scatter of the next).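

In this assay the change from 4-chlorophenyl to 4-nitrophenyl, on an aromatic carbon para to a large group, can now be read on its own: a 1.2-fold higher number from compound 2 to compound 3 (0.09 log units; within the scatter) shows that nitro and chloro cannot be told apart at this position. With the nitro group held in place, 3-bromo-4-fluorophenyl in place of 4-bromophenyl on a carbonyl carbon gives a 3.2-fold higher number from compound 1 to compound 3 (0.51 log units; beyond the scatter) and so accounts for a difference that the earlier pair could not assign to either place. Nothing available explains either reading.

As far as these compounds go, whether nitro and chloro also match when 4-bromophenyl sits on the carbonyl carbon remains open. Also open, from the compounds shown here alone, is how an amine or a carboxylic acid in place of chloro would read in this assay on this core.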